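The compounds below may be only part of what the source reports. "The series", "measured", "known", "first", "only" and "open" are said of these compounds alone.

Measured in an ADME assay on Vero cells (Chlorocebus sabaeus) for cytotoxicity, read by MTT assay, with a stated time of 72 h; a higher number here means that more compound is tolerated, a lower number that less compound is tolerated:
Compound 1 `COc1ccc(/C=C(\C)C(=O)/C=C/c2cccc(Br)c2)cc1`: 153000 nM
Compound 2 `COc1ccc(/C=C(\C)C(=O)/C=C/c2cccc(Cl)c2Cl)cc1`: 119000 nM
Compound 3 `CC/C(=C\c1ccc(Cl)cc1)C(=O)/C=C/c1ccc(Cl)cc1`: 28300 nM

Compound 1, at 153000 nM, has the highest number of the three, although compound 2, at 119000 nM, lies within the scatter of it. Only compound 3, at 28300 nM, stands clearly apart from compound 1, lying lower by more than the scatter.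

The next compound is compound 4 `COc1ccc(/C=C(\C)C(=O)/C=C/c2ccc(Cl)cc2)cc1`, which carries 4-chlorophenyl in place of 3-bromophenyl on a double-bonded chain carbon bound to a double-bonded chain carbon. Among the measured compounds shown here, no step between measured compounds isolates this change, so the expectation rests on indirect evidence. The closest guide is compound 2, at 119000 nM, which also bears chlorine on this ring and shares the rest of compound 1. Compound 3 also bears a 4-chlorophenyl group but differs elsewhere too, so it only hints at a lower number.

The expected 1.5-fold lower number from compound 1 to compound 4 (0.18 log units; within the scatter) is slightly downward and stays within the scatter. For compound 4 the estimated value is 100000 nM, with an expected range of 45000 nM to 200000 nM.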

Compound 4, half-maximal cytotoxic concentration: 87000 nM
Estimate against measurement, compound 4: 1.1-fold (0.06 log units) above, within the range that was stated.
By their numbers in this assay, from the lowest: compound 3; then compounds 4, 2 and 1 (each within the scatter of the next).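

In this assay, among the compounds shown here, the exchange of 3-bromophenyl for 4-chlorophenyl on a double-bonded chain carbon bound to a double-bonded chain carbon gives a 1.8-fold lower number from compound 1 to compound 4 (0.25 log units; within the scatter), the first step at this place in which nothing else in the core of compound 1 changes, and this exchange stays within the scatter. The step alters the halogen and its place on the ring together, so it cannot show what either alteration does alone. No measurement at hand accounts for the result.

The compounds shown leave open whether a phenyl ring bearing an amine or a carboxylic acid would also stay within the scatter of compound 1. Also open, from the compounds shown here alone, is how a longer chain in place of the ring at this position would read.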